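This account rests on a few compounds, and the source may have more. Where it says the series, first, only, none or still open, it means among the compounds named here.

Measured compounds:
compound 1 `CCc1cc2ccccc2nc1-c1cn(-c2ccc(F)cc2)nn1`, > 100 ug/mL
compound 2 `CCCc1cc2ccccc2nc1-c1cn(-c2ccc(F)cc2)nn1`, > 100 ug/mL
compound 3 `CCc1cc2ccccc2nc1-c1cn(CCC(F)(F)C(F)(F)C(F)(F)C(F)(F)C(F)(F)C(F)(F)C(F)(F)C(F)(F)F)nn1`, > 100 ug/mL

In a functional assay on HeLa cells (Homo sapiens) for cytotoxicity, read by MTT assay, with a stated time of 24 h (a higher number here means a weaker inhibitor, a lower number a stronger inhibitor), compound 1 gives only a limit, > 100 ug/mL. Compound 2 likewise reaches only a limit in this assay, > 100 ug/mL. Compound 3 also gives only a limit in this assay, > 100 ug/mL. The change from compound 1 to compound 2 is methyl in place of hydrogen on a saturated chain carbon, two bonds along the chain from an aromatic carbon; the step that the two limits leave unreadable from compound 1 to compound 2 is unreadable because of the limit of > 100 ug/mL in this assay, at which 3 of the 3 values shown sit. Compound 4 `CCCc1cc2ccccc2nc1-c1cn(CCC(F)(F)C(F)(F)C(F)(F)C(F)(F)C(F)(F)C(F)(F)C(F)(F)C(F)(F)F)nn1` is not yet measured; it arises from compound 3 by methyl in place of hydrogen on a saturated chain carbon, two bonds along the chain from an aromatic carbon, the same change. The difference between the cores of compound 1 and compound 3 is not broken down here. The step that the limit leaves unreadable from compound 3 to compound 4 is expected to be small, resting on the unreadable step that the two limits leave unreadable from compound 1 to compound 2. Compound 4 is expected to give 150 ug/mL in this assay, most likely again only as a limit, within 80 ug/mL to 400 ug/mL.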

Compound 4, half-maximal inhibitory concentration: 37.8 ug/mL
Estimate against measurement, compound 4: 4.0-fold (0.60 log units) above; measured number outside the range, below it.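

In this assay, methyl in place of hydrogen on a saturated chain carbon, two bonds along the chain from an aromatic carbon gives an at least 2.6-fold lower number from compound 3 to compound 4 (0.42 log units; beyond the scatter), so the change produces a readable step on the core of compound 3. On the core of compound 1 the same change cannot be read, and its size on the two cores cannot be compared, because both ends of that step are limits: the limit of > 100 ug/mL in this assay, at which 3 of the 4 values shown sit. The result shows that the change can matter on one core, not that it carries over, or fails to carry over, from one core to another.

A longer chain than propyl, or an amine in its place, remains open in the compounds shown. From the compounds shown here alone, whether the step recurs on any further core also remains open.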